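Swapping the Aryl on the Piperazine Nitrogen, Second Time

The source may hold more compounds than are shown below. What is called first, only, known or untested is meant among the compounds shown, and "the series" means these compounds.

Compound 1 `O=C(CN1CCN(c2cccc(Cl)c2)CC1)N1CCN(c2nnc(-c3ccccc3)c(-c3ccccc3)n2)CC1` and compound 2 `COc1ccc(N2CCN(CC(=O)N3CCN(c4nnc(-c5ccccc5)c(-c5ccccc5)n4)CC3)CC2)cc1` share one core and differ in a single place. In a functional assay on MCF7 cells (Homo sapiens) for cytotoxicity, read by MTT assay, with a stated time of 24 h (on this read-out lower numbers stand for stronger inhibition and higher numbers for weaker inhibition), compound 1 gives 56300 nM. For compound 2 this assay reports only a limit, > 910000 nM. The change between them is 4-methoxyphenyl in place of 3-chlorophenyl on an amine nitrogen in a ring, and it produced an at least 16-fold higher number from compound 1 to compound 2 (1.20 log units; beyond the scatter), a step that rests on (the limit of > 910000 nM in this assay, at which 1 of the 3 values shown sits).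

Compound 3 `O=C(CN1CCN(c2cccc(Cl)c2)CC1)N1CCN(c2nnc(-c3ccc(Cl)cc3)c(-c3ccc(Cl)cc3)n2)CC1` carries a different core from compound 1; how the two cores differ is not broken down here. For compound 3 this assay reports only a limit, > 803000 nM. That reading is the limit of > 803000 nM in this assay, at which 1 of the 3 values shown sits.

Compound 4 `COc1ccc(N2CCN(CC(=O)N3CCN(c4nnc(-c5ccc(Cl)cc5)c(-c5ccc(Cl)cc5)n4)CC3)CC2)cc1` has not yet been measured in this assay. It stands to compound 3 as compound 2 stands to compound 1: the change is 4-methoxyphenyl in place of 3-chlorophenyl on an amine nitrogen in a ring. The place of the change reads the same word for word in both pairs, so this is the same kind of change on a different core. Compound 3 already sits at a limit in this assay. The estimate for compound 4 therefore implies a step that the limit leaves unreadable from compound 3 to compound 4, which is expected because the same change gave an at least 16-fold higher number from compound 1 to compound 2 (1.20 log units; beyond the scatter). Compound 4 is expected to give 1000000 nM in this assay, most likely reported again only as a limit, with a plausible span from 500000 nM to 3000000 nM.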

Compound 4, half-maximal inhibitory concentration: > 809000 nM
Compound 4: no number, only a limit; the forecaster's own chance of this, stated with the estimate: 90%; the middle value lies beyond the limit too.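

In this assay compound 4 is reported only as a limit, > 809000 nM. Compound 3 is also reported only as a limit, > 803000 nM, so no step can be read between compound 3 and compound 4. The compounds shown leave open how far 4-methoxyphenyl in place of 3-chlorophenyl moves the number on the core of compound 3, as neither compound has an exact value in this assay.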